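The source may hold more compounds than are shown below. What is called first, only, known or untested is meant among the compounds shown, and "the series" means these compounds.

Compound 1 `C/C=C/C(=O)Nc1cccc(-c2nc3ccccc3s2)c1` gives in an ADME assay on BJ cells (Homo sapiens) for inhibition, with a stated time of 72 h (a higher number here means that more compound is needed for the effect, a lower number that less compound is needed), only a limit, > 25000 nM.
Compound 2 `O=C(O)/C=C/C(=O)Nc1cccc(-c2nc3ccccc3s2)c1` gives in this assay only a limit, > 25000 nM.
Compound 3 `CN(C)CCC(=O)Nc1cccc(-c2nc3ccccc3s2)c1` gives in this assay only a limit, > 25000 nM.

Compound 3 thus stands where every measured member of the series stands, at the limit of > 25000 nM in this assay, at which 3 of the 3 values shown sit; no number places it above or below compound 1 or compound 2. The measured steps that touch the same carbonyl carbon are all cut off by the limits: a step that the two limits leave unreadable from compound 1 to compound 2, a step that the two limits leave unreadable from compound 1 to compound 3 and a step that the two limits leave unreadable from compound 2 to compound 3. Within the data shown here, none of them gives a readable size, so the series so far shows only that three different groups on that carbonyl carbon leave the read-out beyond the limit.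

Compound 4 `O=C(Nc1cccc(-c2nc3ccccc3s2)c1)c1cnccc1Cl` is the next member. The change from compound 3 is 4-chloropyridin-3-yl in place of 2-(dimethylamino)ethyl on a carbonyl carbon. The measured steps bear on the same position but offer no readable size, so no direction can be taken from them; the expectation in this assay is a step that the limit leaves unreadable from compound 3 to compound 4, most likely again a limit rather than a number. For compound 4 the estimate is 30000 nM, with a range from 8000 nM to 100000 nM.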

Compound 4, half-maximal effective concentration: > 25000 nM
Compound 4 was reported as a limit (the forecaster's own chance of this, stated with the estimate: 80%); the middle value lies beyond the limit too.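

Compound 4 also gives only a limit in this assay, so none of its steps from compound 1, compound 2 or compound 3 can be read: the limit of > 25000 nM in this assay, at which 4 of the 4 values shown sit.

The compounds shown leave open whether any group on this carbonyl carbon gives a number rather than a limit, and how far compounds 1 to 4 differ.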